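A few compounds are considered here, and "the series" means these few. Any claim that something is new, unique, unknown or untested is made for them only; others in the source may bear on it.

In a functional assay on MGC-803 cells (Homo sapiens) for inhibition, read by MTT assay, with a stated time of 48 h (on this read-out lower numbers stand for stronger inhibition and higher numbers for weaker inhibition), the measured compounds give:
- Compound 1 `COc1ccc(CN(C(=O)C=C(C)C)c2cc(OC)c(OC)c(OC)c2)cc1O`: 320 nM
- Compound 2 `C#CC(=O)N(Cc1ccc(OC)c(O)c1)c1cc(OC)c(OC)c(OC)c1`: 170 nM
- Compound 3 `COc1ccc(CN(C(=O)C2CC2)c2cc(OC)c(OC)c(OC)c2)cc1O`: 59 nM

Of these three, compound 3 has the lowest number, 59 nM. Compound 4 `COc1ccc(CN(C(=O)CBr)c2cc(OC)c(OC)c(OC)c2)cc1O` carries bromomethyl in place of cyclopropyl on a carbonyl carbon. For the measured compounds named here, no measured compound has bromomethyl there, so the guide is indirect. Two measured steps end at cyclopropyl: a 2.9-fold lower number from compound 2 to compound 3 (0.46 log units; beyond the scatter) and a 5.4-fold lower number from compound 1 to compound 3 (0.73 log units; beyond the scatter). Both other groups thus gave higher numbers than cyclopropyl, and a modest rise is therefore expected in this assay, though with wide uncertainty. The expected change is a 2.0-fold higher number from compound 3 to compound 4 (0.31 log units; beyond the scatter). For compound 4, the estimated value is 120 nM, with an expected range of 30 nM to 450 nM.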

Compound 4, half-maximal inhibitory concentration: 140 nM
The estimate for compound 4 lay 1.2-fold (0.07 log units) below the measured number; measured number inside the range.
By their numbers in this assay, from the lowest: compound 3; then compounds 4, 2 and 1 (each within the scatter of the next, the first and the last beyond it).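

In this assay, bromomethyl on the carbonyl carbon is a third group that gives a higher number than cyclopropyl, with a 2.4-fold higher number from compound 3 to compound 4 (0.38 log units; beyond the scatter), so cyclopropyl keeps the lowest number of the four. Bromomethyl and ethynyl are not separated, with a 1.2-fold lower number from compound 2 to compound 4 (0.08 log units; within the scatter), while a 2.3-fold lower number from compound 1 to compound 4 (0.36 log units; beyond the scatter) sets bromomethyl apart from 2-methylprop-1-en-1-yl. Nothing available here accounts for these differences. Going by these compounds, whether an amine, a carboxylic acid or a longer carbon chain on this carbonyl carbon would match cyclopropyl stays open, as does how chloromethyl would compare with bromomethyl.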